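The source may hold more compounds than are shown below. What is called first, only, known or untested is meant among the compounds shown, and "the series" means these compounds.

Measured in a functional assay on MGC-803 cells (Homo sapiens) for inhibition, read by sulforhodamine B assay; on this read-out lower numbers stand for stronger inhibition and higher numbers for weaker inhibition:
- compound 1 `Cc1ccc(NC2=CC(=O)c3c(nc4n3[C@H]3OC[C@@H](O)[C@H]3OC4)C2=O)cc1`: 1550 nM
- compound 2 `O=C1C(N2CCCCC2)=CC(=O)c2c1nc1n2[C@H]2OC[C@@H](O)[C@H]2OC1`: > 4000 nM
- compound 3 `O=C1C(Nc2ccc(C(F)(F)F)cc2)=CC(=O)c2c1nc1n2[C@H]2OC[C@@H](O)[C@H]2OC1`: 1860 nM

The value for compound 2 is a limit of the assay, not a number. For the measured compounds named here, only two numbers remain, and compound 3 at 1860 nM lies within the scatter of compound 1 at 1550 nM.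

Next is compound 4 `COc1ccc(NC2=CC(=O)c3c(nc4n3[C@H]3OC[C@@H](O)[C@H]3OC4)C2=O)cc1`, with methoxy in place of trifluoromethyl on an aromatic carbon, para to a large group: methoxy in place of trifluoromethyl on an aromatic carbon.

Going by the values given here, the one measured step at that carbon is a 1.2-fold higher number from compound 1 to compound 3 (0.08 log units; within the scatter). The step of an at least 2.5-fold higher number from compound 1 to compound 2 (0.41 log units; beyond the scatter) concerns a double-bonded ring carbon instead and bears little on this change.

In this assay no shift beyond the scatter is therefore expected, and the expected step is a 1.1-fold lower number from compound 3 to compound 4 (0.04 log units; within the scatter).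

For compound 4 the estimate is 1700 nM, with an expected range of 900 nM to 3200 nM.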

Compound 4, half-maximal inhibitory concentration: 2150 nM
The estimate for compound 4 lay 1.3-fold (0.10 log units) below the measured number; low and high end bracket the measured number.
By their numbers in this assay, from the lowest: compounds 1, 3 and 4 (each within the scatter of the next). At a limit, above all of these: compound 2.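

In this assay, methoxy in place of trifluoromethyl on the aromatic carbon para to a large group gives a 1.2-fold higher number from compound 3 to compound 4 (0.06 log units; within the scatter), and methoxy in place of methyl gives a 1.4-fold higher number from compound 1 to compound 4 (0.14 log units; within the scatter). Methyl, trifluoromethyl and methoxy at this carbon therefore all lie within the scatter of one another, which extends the earlier single comparison to all three groups. Compound 2 is a limit and not a number, so an at least 1.8-fold lower number from compound 2 to compound 4 (0.26 log units; that floor lies within the scatter) fixes only a floor: the limit of > 4000 nM in this assay, at which 1 of the 4 values shown sits.

Open, going by these compounds, is whether an amine or a carboxylic acid at this carbon would shift the number beyond the scatter.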